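Removing the acetoxy group: stability of compound 4 estimated

The compounds below may be only part of what the source reports. "The series", "measured", "known", "first", "only" and "open" are said of these compounds alone.

Measured compounds:
Compound 1 `CS(=O)(=O)NC1CCC(CN2CCN(c3cc(=O)c4cc(C(F)(F)F)cc([N+](=O)[O-])c4s3)CC2)CC1`: 111%
Compound 2 `O=C(OC1CCC(CN2CCN(c3cc(=O)c4cc(C(F)(F)F)cc([N+](=O)[O-])c4s3)CC2)CC1)c1cccs1`: 1.8%
Compound 3 `CC(=O)OC1CCC(CN2CCN(c3cc(=O)c4cc(C(F)(F)F)cc([N+](=O)[O-])c4s3)CC2)CC1`: 0%

In an ADME assay on cells (Hepatocyte, Mus musculus) for metabolic stability, with a stated time of 30 min (a lower number here means that less of the compound is left, a higher number that more of the compound is left), compound 3 gives 0%, the lowest of the three numbers, though compound 2 sits within the scatter of it. Compound 1 stands far above both: a number 111 percentage points lower from compound 1 to compound 3 (beyond the scatter) and a number 109.2 percentage points lower from compound 1 to compound 2 (beyond the scatter), while a number 1.8 percentage points lower from compound 2 to compound 3 (within the scatter).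

Compound 4 `O=c1cc(N2CCN(CC3CCCCC3)CC2)sc2c([N+](=O)[O-])cc(C(F)(F)F)cc12` differs from compound 3 in one place: hydrogen in place of acetoxy on a saturated ring carbon. Among the compounds with values here, no measured step shows hydrogen in place of acetoxy, so the bearing steps are indirect. The two low values belong to compounds 2 and 3, which both carry a carbonyloxy group on the saturated ring carbon; compound 4 carries none, as compound 1 carries none. Within the data shown here, a rise beyond the scatter is therefore expected, but its size is uncertain, since the only high value comes from a methanesulfonamido group that compound 4 also lacks. Compound 4 is expected to give about 45%, estimated between 10% and 90%, which means an expected step of a number 45 percentage points higher from compound 3 to compound 4 (beyond the scatter).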

Compound 4, percent of the compound remaining: 80.6%
The estimate for compound 4 lay 35.6 percentage points below the measured number; measured number inside the range.
By their numbers in this assay, from the lowest: compounds 3 and 2 (each within the scatter of the next); then compound 4; then compound 1.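

In this assay the steps of a number 80.6 percentage points higher from compound 3 to compound 4 (beyond the scatter) and a number 78.8 percentage points higher from compound 2 to compound 4 (beyond the scatter) are both large. They show that the low numbers go with the carbonyloxy groups on the saturated ring carbon and not with the shared core. A high number at this position therefore does not depend on the methanesulfonamido group of compound 1, since the plain cyclohexylmethyl of compound 4 already reaches a high number. Hydrogen does not fully match that group, however, as the step of a number 30.4 percentage points lower from compound 1 to compound 4 (beyond the scatter) still separates the two.

Going by these compounds, whether an amine, a carboxylic acid or a carboxamide on the same ring carbon would stand nearer compound 4 or compound 3 remains open. Nothing measured here explains why these numbers differ.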